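This account rests on a few compounds, and the source may have more. Where it says the series, first, only, none or still open, it means among the compounds named here.

Measured compounds:
- compound 1 `Nc1scc(CN2CCN(c3cccc(F)c3F)CC2)c1C(=O)c1ccc(Cl)cc1`: -13%
- compound 2 `Nc1scc(CN2CCN(c3cccc(Cl)c3)CC2)c1C(=O)c1ccc(Cl)cc1`: -3.1%

In a functional assay on CHO cells with adenosine receptor A1 (Homo sapiens) as the target, read by cAMP accumulation and immunoassay, with a stated time of 6 min, tested at 0.01 uM (a lower number here means a stronger effect, a higher number a weaker effect of the compound at the concentration tested), compound 1 gives -13% and compound 2 gives -3.1%. Compound 2 holds the higher of the two numbers, but the step of a number 9.9 percentage points higher from compound 1 to compound 2 (within the scatter) lies within the scatter, so the two compounds cannot be told apart on this evidence.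

Compound 3 `Nc1scc(CN2CCN(c3ccccc3Cl)CC2)c1C(=O)c1ccc(Cl)cc1` is not yet measured. It differs from compound 2 by 2-chlorophenyl in place of 3-chlorophenyl on an amine nitrogen in a ring. Among the compounds with values here, the only measured step that bears on this change is the aryl swap on the same ring nitrogen, a number 9.9 percentage points higher from compound 1 to compound 2 (within the scatter), which stayed within the scatter. Within the data shown here, two small, near-zero readings at this concentration give no footing for a step of any size, so no change beyond the scatter is expected in this assay, in either direction.

For compound 3 the expected value in this assay is -6%, within -20% to 8%, meaning an estimated step of a number 2.9 percentage points lower from compound 2 to compound 3 (within the scatter).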

Compound 3, a percentage reported as activity, at one concentration (the size of the read-out at that concentration, not a potency): -2.1%
Compound 3: the middle estimate sits 3.9 percentage points below what was measured; measured number inside the range.
By their numbers in this assay, from the lowest: compounds 1, 2 and 3 (each within the scatter of the next, the first and the last beyond it).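

In this assay, within the data shown here, 2-chlorophenyl in place of 3-chlorophenyl on the amine nitrogen in the ring gives a number 1 percentage points higher from compound 2 to compound 3 (within the scatter), so moving the chlorine within the phenyl group gives no readable difference at this position. 2-Chlorophenyl in place of 2,3-difluorophenyl gives a number 10.9 percentage points higher from compound 1 to compound 3 (beyond the scatter), the first step beyond the scatter, but it is modest and compound 2 remains within the scatter of both other compounds, so no firm ranking of the aryl groups follows. Nothing available explains this step.

Open, going by these compounds, is whether a methoxy or trifluoromethyl group on the phenyl, or a pyridyl group in place of the phenyl, would give a step clearly larger than these. Also open, on these data alone, is whether the small step to compound 3 would persist at other concentrations.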